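Bromine Position on the Benzyl Group: Compound 3 to Compound 4

The compounds below may be only part of what the source reports. "The series", "measured", "known", "first", "only" and "open" are said of these compounds alone.

Measured compounds:
compound 1, `O=C(/C=C/c1ccc(OCc2cn(Cc3cccc(Br)c3)nn2)cc1)c1ccc(Br)cc1`, 43%
compound 2, `O=C(/C=C/c1ccc(OCc2cn(Cc3ccccc3)nn2)cc1)c1ccc([N+](=O)[O-])cc1`, "not active" (no number reported)
compound 3, `O=C(/C=C/c1ccc(OCc2cn(Cc3ccccc3Br)nn2)cc1)c1ccc([N+](=O)[O-])cc1`, 34%

In a functional assay on MIA PaCa-2 cells (Homo sapiens) for inhibition, read by MTT assay, with a stated time of 48 h, tested at 10 uM (on this read-out higher numbers stand for more inhibition of growth at the one concentration tested and lower numbers for less inhibition of growth), compound 3 gives 34%, and compound 1 gives 43%; the two lie within the scatter of each other. Compound 2 is reported in this assay without a number.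

Compound 4, `O=C(/C=C/c1ccc(OCc2cn(Cc3cccc(Br)c3)nn2)cc1)c1ccc([N+](=O)[O-])cc1`, differs from compound 3 by 3-bromophenyl in place of 2-bromophenyl on a saturated chain carbon bound to an aromatic nitrogen. For the measured compounds named here, no measured pair shows this change, so the step is expected to stay within the scatter, in either direction. Compound 4 is therefore estimated at 38%, between 20% and 55%, a step of a number 4 percentage points higher from compound 3 to compound 4 (within the scatter).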

Compound 4, percent growth inhibition at one concentration: 21%
Estimate against measurement, compound 4: 17 percentage points above; the measured number falls inside the stated range.
By their numbers in this assay, from the lowest: compound 4; then compounds 3 and 1 (each within the scatter of the next).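

In this assay, 3-bromophenyl in place of 2-bromophenyl gives a number 13 percentage points lower from compound 3 to compound 4 (beyond the scatter), showing that this read-out separates two groups with the same atoms, joined differently, at this position. With the 3-bromobenzyl group held constant, nitro in place of bromo on an aromatic carbon gives a number 22 percentage points lower from compound 1 to compound 4 (beyond the scatter), so the aromatic substituent on the other side of the molecule also changes the number. No available evidence accounts for either step. The compounds shown leave open how an amine or a carboxylic acid in place of the bromine on the benzyl group would read.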